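The compounds below may be only part of what the source reports. "The series", "measured", "known", "first", "only" and "open" are said of these compounds alone.

Compound 1 `Brc1ccc(-c2nc(-c3ccc4nc[nH]c4c3)no2)cc1` and compound 2 `Fc1ccc(-c2nc(-c3ccc4nc[nH]c4c3)no2)cc1` share one core and differ only in the halogen. In a physicochemical assay for solubility, using potentiometric titration (a lower number here means a less soluble compound, a higher number a more soluble compound), compound 1 gives 35400 nM. In this assay, among the compounds with values here, compound 2 gives 66900 nM; its only neighbour is compound 1, and a 1.9-fold higher number from compound 1 to compound 2 (0.28 log units; within the scatter). Compound 3 `OCCCCCc1ccc(-c2nc(-c3ccc4nc[nH]c4c3)no2)cc1` carries 5-hydroxypentyl in place of fluoro on an aromatic carbon. Within the data shown here, no measured step exchanges a halogen for a hydroxyalkyl chain; the sole step, a 1.9-fold higher number from compound 1 to compound 2 (0.28 log units; within the scatter), swaps one halogen for another and gives little guidance. For compound 3 a step of a 1.2-fold higher number from compound 2 to compound 3 (0.08 log units; within the scatter) is expected, with wide uncertainty. In this assay compound 3 is estimated at 80000 nM, between 25000 nM and 250000 nM.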

Compound 3, solubility: 37500 nM
For compound 3 the middle estimate is 2.1-fold (0.33 log units) above the measured one; low and high end bracket the measured number.
By their numbers in this assay, from the lowest: compounds 1, 3 and 2 (each within the scatter of the next).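

On an aromatic carbon para to a large group, the shared core now carries a 5-hydroxypentyl chain as well as a halogen, and in this assay neither replacement gives a step beyond the scatter (a 1.8-fold lower number from compound 2 to compound 3 (0.25 log units; within the scatter); a 1.1-fold higher number from compound 1 to compound 3 (0.03 log units; within the scatter)). The three substituents therefore cannot be told apart by their numbers, although the entering chain has 6 heavy atoms and brings a hydrogen-bond donor. No measurement at hand explains this result.

From the compounds shown here alone, whether an amine, a carboxylic acid or a longer chain at this position would give a step beyond the scatter remains open. Also open, going by these compounds, is whether a plain pentyl chain without the hydroxyl would read the same.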